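The compounds below may be only part of what the source reports. "The series", "measured", "known", "first", "only" and "open" are said of these compounds alone.

In a functional assay on A549 cells (Homo sapiens) for antiproliferative activity, read by MTT assay, with a stated time of 72 h (on this read-out higher numbers stand for weaker inhibition and lower numbers for stronger inhibition), three related compounds have been measured. Compound 1 `CC(C)(C)OC(=O)N1CCN(C(=S)SCc2cn(C[C@H](O)[C@H]3OC(=O)C(OCc4ccccc4)=C3OCc3ccccc3)nn2)CC1` gives > 100000 nM, which is a limit of the assay and not a number. Compound 2 `COc1ccccc1-c1cn(C[C@H](O)[C@H]2OC(=O)C(OCc3ccccc3)=C2OCc2ccccc2)nn1` gives > 100000 nM, again only a limit. Compound 3 `COc1ccc(-c2cn(C/C=C3\OC(=O)C(OCc4ccccc4)=C3OCc3ccccc3)nn2)cc1` gives > 100000 nM, likewise a limit. Compound 2 therefore cannot be ranked against the other two, and the whole picture is a single one: the limit of > 100000 nM in this assay, at which 3 of the 3 values shown sit.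

Compound 4 `O=C1O[C@H]([C@@H](O)Cn2cc(CCCCl)nn2)C(OCc2ccccc2)=C1OCc1ccccc1` carries 3-chloropropyl in place of the 2-methoxyphenyl of compound 2, on an aromatic carbon of a five-membered aromatic ring with 3 nitrogen: 3-chloropropyl in place of 2-methoxyphenyl on an aromatic carbon. Among the measured compounds shown here, no step between measured compounds is available to size this change in this assay. Only a small strengthening is expected, and the estimated change is an at least 1.4-fold lower number from compound 2 to compound 4 (0.15 log units; that floor lies within the scatter). A further result reported only as a limit would be no surprise. For compound 4 the expected half-maximal inhibitory concentration is 70000 nM, with an estimated range from 20000 nM to 200000 nM.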

Compound 4, half-maximal inhibitory concentration: 29000 nM
Estimate against measurement, compound 4: 2.4-fold (0.38 log units) above; measured number inside the range.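

In this assay, the aromatic carbon of the five-membered aromatic ring with 3 nitrogen proves to be a place where a change of group can be read: 3-chloropropyl in place of 2-methoxyphenyl gives an at least 3.4-fold lower number from compound 2 to compound 4 (0.53 log units; beyond the scatter). This step is a floor, and its full size cannot be read. Compound 4 alone gives a number, while the other compounds stay at a single value: the limit of > 100000 nM in this assay, at which 3 of the 4 values shown sit.

The compounds shown leave open whether the chlorine, the open chain or the loss of the six-membered aromatic ring goes with the lower number, as all of these change together in this one step. A plain propyl chain, a longer chain ending in chlorine, or a propyl chain ending in an amine would be needed to tell these apart.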